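The source may hold more compounds than are shown below. What is called first, only, known or untested is meant among the compounds shown, and "the series" means these compounds.

Compound 1 `O=C(NCCCCCCS)c1cc(-c2ccc(-c3ccccc3)cc2)n[nH]1`: > 50000 nM, a limit.
Compound 2 `C=CCOC(=O)SCCCCCCNC(=O)c1cc(-c2ccncc2)n[nH]1`: 12600 nM.
Compound 3 `O=C(NCCCCCCS)c1cc(-c2ccc3ccccc3c2)n[nH]1`: > 50000 nM, a limit.

All three were tested in a functional assay on MCF7 cells (Homo sapiens) for inhibition, read by MTT assay, with a stated time of 96 h; on this read-out lower numbers stand for stronger inhibition of growth and higher numbers for weaker inhibition of growth. Compound 2 stands alone with a measured number, at 12600 nM. The results for compound 1 and compound 3 are limits only. Compound 4 `CSCCCCCCNC(=O)c1cc(-c2ccncc2)n[nH]1` keeps the core and chain of compound 2, with methyl in place of allyloxycarbonyl on a sulfur. For the measured compounds named here, no measured pair shows this change directly. The data contain (the limit of > 50000 nM in this assay, at which 2 of the 3 values shown sit), so weaker inhibition of growth is expected in this assay, by a moderate step beyond the scatter. The estimated 2.8-fold higher number from compound 2 to compound 4 (0.44 log units; beyond the scatter) leaves a result reported only as a limit quite possible. For compound 4 the expected value is 35000 nM, with an estimated range of 12000 nM to 60000 nM.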

Compound 4, concentration for 50% growth inhibition: > 50000 nM
Compound 4: no number, only a limit; the forecaster's own chance of this, stated with the estimate: 55%; middle value at least 1.4-fold (0.15 log units) away from the limit.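

In this assay, for the compounds shown here, this is the first step that can be read at the sulfur, and it gives an at least 3.9-fold higher number from compound 2 to compound 4 (0.59 log units; beyond the scatter), so methyl in place of allyloxycarbonyl on a sulfur weakens inhibition of growth beyond the scatter. Compound 4 gives > 50000 nM, which is a limit, so this step has a floor but no measured size. Compound 2 keeps the only measured number in the set: the limit of > 50000 nM in this assay, at which 3 of the 4 values shown sit.

The compounds shown leave open what acetyl or benzoyl on that sulfur would give with the same core and chain. They also leave open whether a hydrogen there, as a free thiol, would give a measured number with this core.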